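The compounds below may be only part of what the source reports. "The series", "measured", "known", "first", "only" and "open" are said of these compounds alone.

Compound 1 `CC1=CCCC(C)(C)C1/C=C/C(=O)/C=C/c1ccccc1F` and compound 2 `CC1=CCCC(C)(C)C1/C=C/C(=O)/C=C/c1cc(C(F)(F)F)ccc1F` share one core, while compound 3 `CC1=C(/C=C/C(=O)/C=C/c2ccccc2)C(C)(C)CCC1O` and compound 4 `CC1=C(/C=C/C(=O)/C=C/c2ccc(C(F)(F)F)cc2)C(C)(C)CCC1O` share another; the difference between the two cores is not broken down here. In a functional assay on CWR22R cells (Homo sapiens) for cytotoxicity, read by MTT assay, with a stated time of 72 h (a lower number here means a stronger inhibitor, a higher number a weaker inhibitor), compound 1 gives 9400 nM, and compound 2 gives 3500 nM, so the change trifluoromethyl in place of hydrogen on an aromatic carbon brought a 2.7-fold lower number from compound 1 to compound 2 (0.43 log units; beyond the scatter). Compound 3 gives 8000 nM in this assay. Compound 4 carries the same kind of change, (trifluoromethyl in place of hydrogen on an aromatic carbon), though here the new group sits para to a large group, whereas in compound 2 it sits meta to a large group and para to a fluoro group. Resting on that single earlier step, the step expected from compound 3 to compound 4 in this assay is a 2.0-fold lower number from compound 3 to compound 4 (0.30 log units; within the scatter). Compound 4 is therefore estimated at 4000 nM, expected to fall between 1500 nM and 10000 nM.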

Compound 4, half-maximal inhibitory concentration: 3200 nM
Beside the measured number, compound 4's estimate is 1.3-fold (0.10 log units) above it; the measured number falls inside the stated range.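

In this assay, trifluoromethyl in place of hydrogen on an aromatic carbon brought a 2.5-fold lower number from compound 3 to compound 4 (0.40 log units; beyond the scatter), and the step kept much the same size on both cores: the same change on two cores in this assay, a 2.7-fold lower number (0.43 log units; beyond the scatter) from compound 1 to compound 2 and a 2.5-fold lower number (0.40 log units; beyond the scatter) from compound 3 to compound 4, 1.1-fold (0.03 log units) apart, within the scatter of two such steps. The agreement held even though the new group's place on the aromatic ring differs between the two pairs. For the compounds shown here, still, it rests on only two pairs in a single cell assay, so it does not show that the change would carry to other cores, nor why the number falls.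

The compounds shown leave open whether a nitrile, a methoxy group or an amine in place of that hydrogen would move the number as trifluoromethyl does. They also leave open whether a longer chain carrying fluorine would do the same.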